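Hydrazone aryl swaps on the shared diaryl ether urea core

The source may hold more compounds than are shown below. What is called first, only, known or untested is meant among the compounds shown, and "the series" means these compounds.

Three members of the series have numbers in a functional assay on HT-29 cells (Homo sapiens) for cytotoxicity, read by MTT assay, with a stated time of 72 h; on this read-out higher numbers stand for weaker inhibition and lower numbers for stronger inhibition. Compound 1 `CN(C)CCn1cnnc1-c1cc(Oc2ccc(NC(=O)N/N=C/c3cc(C(C)(C)C)cc(C(C)(C)C)c3O)cc2F)ccn1` gives 680 nM, compound 2 `Cn1ncnc1-c1cc(Oc2ccc(NC(=O)N/N=C/c3ccccc3)cc2F)ccn1` gives 30200 nM and compound 3 `COc1cc(/C=N/NC(=O)Nc2ccc(Oc3ccnc(-c4nncn4CCN(C)C)c3)c(F)c2)cc(OC)c1OC` gives 3620 nM. Compound 3 therefore stands second highest of the three: its nearest neighbour is compound 1, with a number lower by a margin beyond the scatter, and its furthest is compound 2, with a number higher by a margin beyond the scatter. For the measured compounds named here, no two measured compounds differ in a single place, so none of these gaps can be tied to one change alone; compound 2 also carries a different group on the triazole.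

The next member, compound 4 `CN(C)CCn1cnnc1-c1cc(Oc2ccc(NC(=O)N/N=C/c3ccc(F)cc3Cl)cc2F)ccn1`, is reached from compound 3 by one change at the carbon with a double bond to nitrogen: 2-chloro-4-fluorophenyl in place of 3,4,5-trimethoxyphenyl on a carbon with a double bond to nitrogen. Going by the values given here, a step between compound 3 and compound 4 in this assay is expected to be modest and towards a higher number, since the only measured compound with a small, acceptor-free aryl on that carbon, compound 2, gives 30200 nM, while the lowest number, from compound 1 at 680 nM, goes with a far larger aryl. The expected step is a 1.7-fold higher number from compound 3 to compound 4 (0.22 log units; within the scatter). For compound 4 the estimate in this assay is 6000 nM, with a range from 1800 nM to 20000 nM.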

Compound 4, half-maximal inhibitory concentration: 510 nM
Estimate against measurement, compound 4: 12-fold (1.07 log units) above, and the stated range ends above it.
By their numbers in this assay, from the lowest: compounds 4 and 1 (each within the scatter of the next); then compound 3; then compound 2.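

In this assay, 2-chloro-4-fluorophenyl in place of 3,4,5-trimethoxyphenyl on a carbon with a double bond to nitrogen gives a 7.1-fold lower number from compound 3 to compound 4 (0.85 log units; beyond the scatter). For the compounds shown here, this is the first step with only one place changed, and it shows that this position alone can move the number by a margin beyond the scatter. The entering aryl has fewer heavy atoms than the leaving aryl and 0 hydrogen-bond acceptors against 3, so in this pair the smaller, acceptor-free aryl goes with the lower number, and no other measurement bears on why.

The pair cannot separate the contribution of the chlorine, the fluorine and the loss of the three methoxy groups, since all of these change in one step. Also open, from the compounds shown here alone, is how the number responds on this carbon to a single halogen, such as 4-fluorophenyl or 2-chlorophenyl alone, or to an aryl carrying an amine or a carboxylic acid, with the rest of compound 4 kept as it is.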